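A Small Series Meets a Trifluoromethyl Swap

The compounds below may be only part of what the source reports. "The series", "measured", "known", "first", "only" and "open" are said of these compounds alone.

Of the compounds shown here, three that share a core have been tested in a functional assay on MIA PaCa-2 cells (Homo sapiens) for inhibition, read by MTT assay, with a stated time of 72 h; a lower number here means a stronger inhibitor, a higher number a weaker inhibitor. There, compound 1 `COc1cc(NC(C)CCCNC(=O)Nc2cccc(F)c2)c2ncccc2c1` gives 22000 nM, compound 2 `COc1cc(NC(C)CCCNC(=O)Nc2cccc(Cl)c2)c2ncccc2c1` gives 21000 nM, and compound 3 `COc1cc(NC(C)CCCNC(=O)Nc2ccc(F)cc2)c2ncccc2c1` gives 21000 nM. Compound 3 therefore stands level with compound 2, and all three numbers lie within the usual scatter of one another.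

The next compound, compound 4 `COc1cc(NC(C)CCCNC(=O)Nc2ccc(C(F)(F)F)cc2)c2ncccc2c1`, differs from compound 3 in one group: trifluoromethyl in place of fluoro on an aromatic carbon. Put simply, trifluoromethyl takes the place of fluoro on an aromatic carbon, para to a large group.

Going by the values given here, three measured steps bear on this swap. Chloro in place of fluoro on an aromatic carbon gave a 1.0-fold lower number from compound 1 to compound 2 (0.02 log units; within the scatter). The change to 4-fluorophenyl in place of 3-fluorophenyl gave a 1.0-fold lower number from compound 1 to compound 3 (0.02 log units; within the scatter), and the change to 4-fluorophenyl in place of 3-chlorophenyl gave no change at the digits printed from compound 2 to compound 3 (within the scatter). Among the compounds with values here, none of these changes moved the number beyond the scatter, although no tested compound yet carries trifluoromethyl. In this assay, the expectation is therefore no real shift in either direction. The estimated step is a 1.2-fold lower number from compound 3 to compound 4 (0.07 log units; within the scatter), which is no larger than the scatter. For compound 4, the estimated value is 18000 nM, with an expected range from 9000 nM to 35000 nM.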

Compound 4, half-maximal inhibitory concentration: 8400 nM
Compound 4: the middle estimate sits 2.1-fold (0.33 log units) above what was measured, outside the stated range (below it).
By their numbers in this assay, from the lowest: compound 4; then compounds 2, 3 and 1 (each within the scatter of the next).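

In this assay, putting trifluoromethyl in place of fluoro on this aromatic carbon, para to a large group, gave a 2.5-fold lower number from compound 3 to compound 4 (0.40 log units; beyond the scatter) and moved the number beyond the scatter. This shows that the group at this position can change the result, which the earlier swaps between fluoro and chloro and between ring positions did not reveal. The 4-(trifluoromethyl)phenyl group also stands clear of the 3-chlorophenyl and 3-fluorophenyl groups, with a 2.5-fold lower number from compound 2 to compound 4 (0.40 log units; beyond the scatter) and a 2.6-fold lower number from compound 1 to compound 4 (0.42 log units; beyond the scatter) making the trifluoromethyl compound the strongest inhibitor of the four by a modest margin, and no measurement here explains why.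

This gain rests on a single compound, so the series cannot yet show a trend across groups at this carbon. A nitrile, a methyl group, an amine or a carboxylic acid in the same place would help show whether the gain is specific to trifluoromethyl, and a longer chain in place of the current one would test whether it holds elsewhere in the molecule.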